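The source may report more compounds than this note shows. Statements on the series, on what has been measured and on what is new or still open speak of the compounds shown alone.

Series in a functional assay on HeLa cells (Homo sapiens) for antiproliferative activity, read by MTT assay, with a stated time of 48 h; on this read-out lower numbers stand for stronger inhibition and higher numbers for weaker inhibition:
- compound 1 `COc1cc(-c2nnc3c(OC)cc(-c4ccc5[nH]ccc5c4)cn23)cc(OC)c1OC`: 85 nM
- compound 2 `COc1cc(-c2nnc3c(OC(C)C)cc(-c4ccc5[nH]ccc5c4)cn23)cc(OC)c1OC`: 261 nM
- compound 3 `COc1cc(-c2nnc3c(OC4CCC4)cc(-c4ccc5[nH]ccc5c4)cn23)cc(OC)c1OC`: 142 nM

Compound 1 separates from compound 2 only, with a 3.1-fold higher number from compound 1 to compound 2 (0.49 log units; beyond the scatter). The other step, a 1.7-fold higher number from compound 1 to compound 3 (0.22 log units; within the scatter), stays within the scatter. Compound 4 `COc1cc(-c2nnc3c(OC)cc(-c4ccc5[nH]cc(C=O)c5c4)cn23)cc(OC)c1OC` is the core of compound 1 with 3-formyl-1H-indol-5-yl in place of 1H-indol-5-yl: formyl in place of hydrogen on an aromatic carbon. The measured steps all change the group on an oxygen on an aromatic ring, so they bear only indirectly, as a guide to the size of step this series shows. Within the data shown here, no measured compound carries a group at the new place. A modest move toward a higher number is expected: a 2.6-fold higher number from compound 1 to compound 4 (0.41 log units; beyond the scatter). The estimate for compound 4 is 220 nM, with an expected range of 60 nM to 900 nM.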

Compound 4, half-maximal inhibitory concentration: > 10000 nM
Compound 4 was reported as a limit; the forecaster's own chance of this, stated with the estimate: 5%; at least 45-fold (1.65 log units) between middle value and limit.
By their numbers in this assay, from the lowest: compounds 1, 3 and 2 (each within the scatter of the next, the first and the last beyond it). At a limit, above all of these: compound 4.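

In this assay, formyl in place of hydrogen on an aromatic carbon of the five-membered aromatic ring, two ring bonds from the ring nitrogen, gives an at least 110-fold higher number from compound 1 to compound 4 (2.07 log units; beyond the scatter). Compound 4 stands as a limit and not as a number: the limit of > 10000 nM in this assay, at which 1 of the 4 values shown sits. This place is far more sensitive to change than the group on the oxygen, where compounds 2 and 3 stay much closer to compound 1.

Going by these compounds, whether the loss follows formyl itself or any group at this place stays open. A methyl, a nitrile or an aminomethyl group at the same place would separate the two.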